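The source may hold more compounds than are shown below. What is called first, only, known or untested is meant among the compounds shown, and "the series" means these compounds.

Compound 2 `COC/C=C/c1ccc(CN(C(=O)C2CCCCC2)c2cccc(/C=C/C(=O)OC)c2)cc1` gives 233 nM in an assay on isolated protein with Bile acid receptor (Homo sapiens) as the target (on this read-out higher numbers stand for an effect only at larger amounts of compound and lower numbers for an effect already at smaller amounts), the highest of the two numbers measured; its nearest neighbour, compound 1 `COC(=O)/C=C/c1cccc(N(Cc2ccc(-c3ccc(F)c(Cl)c3)cc2)C(=O)C2CCCCC2)c1`, gives 66 nM. Among the compounds with values here, the only step measured so far, a 3.5-fold higher number from compound 1 to compound 2 (0.55 log units; beyond the scatter), concerns the aryl end and does not bear directly on the next change. Compound 3 `CCOC/C=C/c1ccc(CN(C(=O)C2CCCCC2)c2cccc(/C=C/C(=O)OC)c2)cc1` differs from compound 2 by methyl in place of hydrogen on a saturated chain carbon bound to an oxygen on a saturated carbon. Within the data shown here, no measured step touches this position; with nothing to go on, no change beyond the scatter is expected, a 1.1-fold lower number from compound 2 to compound 3 (0.02 log units; within the scatter). Compound 3 is therefore estimated at 220 nM, within 80 nM to 600 nM.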

Compound 3, half-maximal effective concentration: 198000 nM
For compound 3 the middle estimate is 900-fold (2.95 log units) below the measured one; measured number outside the range, above it.
By their numbers in this assay, from the lowest: compound 1; then compound 2; then compound 3.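

A single added methyl at this position, methoxy to ethoxy on a saturated chain carbon bound to an oxygen on a saturated carbon, gives an 850-fold higher number from compound 2 to compound 3 (2.93 log units; beyond the scatter) in this assay, so the end of this chain is far from tolerant of change. The replacement of 3-chloro-4-fluorophenyl by 3-ethoxyprop-1-en-1-yl now reads a 3000-fold higher number from compound 1 to compound 3 (3.48 log units; beyond the scatter) and far exceeds the step to the methoxy analogue. No available evidence accounts for this jump. Still open, on these data alone, is whether a longer chain such as propoxy stays at this level, and how a terminal hydroxyl or an amine in place of the methoxy would read.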